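Imidazolyl to methylfuranyl on the biaryl ether series

The source may hold more compounds than are shown below. What is called first, only, known or untested is meant among the compounds shown, and "the series" means these compounds.

Measured so far:
compound 1, `c1ccc(-c2ccsc2)c(OCC2=NCCN2)c1`, 12.6 nM in a functional assay for activation of Alpha-1D adrenergic receptor (Homo sapiens), read by calcium flux; a higher number here means that more compound is needed for the effect, a lower number that less compound is needed
compound 2, `c1ccc(-c2ncc[nH]2)c(OCC2=NCCN2)c1`, < 100000 nM in this assay

Compound 2 stands only at a limit in this assay; its value < 100000 nM is a limit of the assay and not a number, as noted in the limit of < 100000 nM in this assay, at which 1 of the 2 values shown sits. The step that the limit leaves unreadable from compound 1 to compound 2 is therefore unreadable in size.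

Compound 3, `Cc1ccoc1-c1ccccc1OCC1=NCCN1`, is not yet measured in this assay. It differs from compound 2 by 3-methylfuran-2-yl in place of 1H-imidazol-2-yl on an aromatic carbon. The change removes the 1H-imidazol-2-yl that compound 2 carries and puts in a five-membered aromatic ring with a single hetero atom, which brings compound 3 closer in shape to compound 1 with its thiophen-3-yl, for which 12.6 nM was read in this assay.

Within the data shown here, no measured step bears directly on this change; the only step in hand, a step that the limit leaves unreadable from compound 1 to compound 2, has no readable size because compound 2 sits at the limit. The direction of the step from compound 2 to compound 3 is expected to be toward less compound needed, but its size cannot be set from the data; the step that the limit leaves unreadable from compound 2 to compound 3 is therefore an estimate of direction more than of size.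

The estimate for compound 3 in this assay is 40 nM, expected to lie between 5 nM and 400 nM.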

Compound 3, half-maximal effective concentration: < 100000 nM
Compound 3 gave a limit, no number; the forecaster's own chance of this, stated with the estimate: 10%; the middle value is on the limit's open side.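

No step among compound 1, compound 2 and compound 3 can be read in this assay, as compound 2 and compound 3 both stand at a limit and not at a number: the limit of < 100000 nM in this assay, at which 2 of the 3 values shown sit.

Still open, as far as these compounds go, is how 1H-imidazol-2-yl and 3-methylfuran-2-yl would compare in size of step with the thiophen-3-yl of compound 1, which gives 12.6 nM.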